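A few compounds are considered here, and "the series" means these few. Any claim that something is new, unique, unknown or untested is made for them only; others in the source may bear on it.

Compounds measured so far:

compound 1, `CCCCc1cnc(C(CCC)Cc2ccc(-c3ccccc3C(=O)O)cc2)[nH]1`: in an in vitro functional assay on cells for agonist activity at Bombesin receptor subtype-3 (Mus musculus), read by luminescence and calcium flux (a higher number here means that more compound is needed for the effect, a lower number that less compound is needed), compound 1 gives 165 nM
compound 2, `CCCCc1cnc(CCCc2ccc(-c3ccccc3C(=O)O)cc2)[nH]1`: in this assay compound 2 gives 382 nM
compound 3, `O=C(O)c1ccccc1-c1ccc(CCc2ncc(CC3CCC3)[nH]2)cc1`: in this assay compound 3 gives 7.1 nM

Compound 3 stands at the lowest of the three numbers in this assay. Against compound 1 it lies beyond the scatter, and against compound 2 it lies further still; the two values of compounds 1 and 2 differ from each other, but no single-point step joins them to compound 3, so only the bare numbers can be compared. Compound 3 carries a cyclobutylmethyl on the shared core; compounds 1 and 2 carry a butyl there with further changes in the linker, so the gap cannot be attributed to one place.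

Compound 4, `O=C(O)c1ccccc1-c1ccc(CCc2ncc(Cc3ccccc3F)[nH]2)cc1`, is the next analogue: 2-fluorophenyl in place of cyclobutyl on a saturated chain carbon bound to an aromatic carbon. The saturated four-membered ring gives way to an aromatic ring bearing a fluorine, with the count of donors and acceptors unchanged. Going by the values given here, no measured pair shows this exact exchange, so the direction is open. The expectation is a small step, not clearly beyond the scatter, with a slight lean toward a higher number: a 1.7-fold higher number from compound 3 to compound 4 (0.23 log units; within the scatter). On that basis compound 4 is estimated at 12 nM in this assay, within a range of 3 nM to 50 nM.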

Compound 4, half-maximal effective concentration: 9.5 nM
The estimate for compound 4 lay 1.3-fold (0.10 log units) above the measured number; the range from low to high includes it.
By their numbers in this assay, from the lowest: compounds 3 and 4 (each within the scatter of the next); then compound 1; then compound 2.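

In this assay, going by these compounds alone, the exchange of cyclobutyl for 2-fluorophenyl on a saturated chain carbon bound to an aromatic carbon gives a 1.3-fold higher number from compound 3 to compound 4 (0.13 log units; within the scatter), the first step that can be read at a single place, and it lies within the scatter. At this place, therefore, the four-membered non-aromatic ring of compound 3 and the fluorine-bearing six-membered aromatic ring of compound 4 cannot be told apart in this read-out, even though the entering group has more heavy atoms and adds a fluorine. No supporting measurement bears on this result, and the step alone offers no explanation of it.

The separate contributions of the aromatic ring and the fluorine remain open, as the compounds shown include no plain benzyl group to divide the exchange into two parts. Also open, on these data alone, is how far this tolerance extends at the same place, for example to a group carrying an amine, a carboxylic acid or a longer chain, and whether any such group would give a step beyond the scatter.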